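Swapping the pyrimidine ether for a simple pyridine ether

The compounds below may be only part of what the source reports. "The series", "measured", "known", "first", "only" and "open" are said of these compounds alone.

Measured compounds:
- compound 1, `CNc1cc(Oc2ccc(NC(=O)Nc3cccc(C(F)(F)F)c3)cc2)ncn1`, 40 nM
- compound 2, `CNc1cc(Oc2ccc(NC(=O)Nc3cccc(C(C)(F)F)c3)cc2)ncn1`, 40 nM

Compound 1 and compound 2 share a urea core and differ only in the group on one outer ring. In an assay on isolated protein for inhibition of serine/threonine-protein kinase TNNI3K (Homo sapiens) (on this read-out higher numbers stand for weaker inhibition and lower numbers for stronger inhibition), compound 1 gives 40 nM, and compound 2 gives 40 nM; the step of no change at the digits printed from compound 1 to compound 2 (within the scatter) shows that this small change at the far end of the molecule left the read-out where it was.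

The unmeasured compound 3, `O=C(Nc1ccc(Oc2ccncc2)cc1)Nc1cccc(C(F)(F)F)c1`, changes a different part of compound 1: pyridin-4-yl in place of 6-(methylamino)pyrimidin-4-yl on an oxygen on an aromatic ring. Among the compounds with values here, no measured step touches this position, so the one step in hand, from compound 1 to compound 2, gives no guide to how large a change to expect here. The group that leaves carries a hydrogen-bond donor and more acceptors than the group that enters, and the ring that enters is smaller, which is a larger alteration than the one already measured. Compound 3 is therefore expected to be a weaker inhibitor in this assay, the step of a 7.5-fold higher number from compound 1 to compound 3 (0.88 log units; beyond the scatter) being the estimate, with wide uncertainty. The value for compound 3 is estimated at 300 nM, within a range from 50 nM to 2000 nM.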

Compound 3, half-maximal inhibitory concentration: 50 nM
The estimate for compound 3 lay 6.0-fold (0.78 log units) above the measured number; the range from low to high includes it.
By their numbers in this assay, from the lowest: compounds 1, 2 and 3 (each within the scatter of the next).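

In this assay, the swap of pyridin-4-yl in place of 6-(methylamino)pyrimidin-4-yl on an oxygen on an aromatic ring gives a 1.3-fold higher number from compound 1 to compound 3 (0.10 log units; within the scatter). The earlier pair showed only that a small edit at the far end of the molecule left the read-out in place, whereas this pair tests a different position and a much larger edit. The entering group is smaller, with no hydrogen-bond donor and fewer hydrogen-bond acceptors, so in this one pair neither the methylamino group nor the second ring nitrogen is needed to stay within the scatter, although no measurement here explains why.

The compounds shown do not tell how this oxygen would tolerate a plain phenyl ring, which has no ring nitrogen at all, or a pyrimidin-4-yl group with no methylamino group, so it remains unknown whether any ring nitrogen matters here. Within the data shown here, it also remains open whether the same swap would hold with a different far-end group, such as a nitrile or a methoxy group, since this position has been tested in only one pair.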